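The compounds below may be only part of what the source reports. "The series", "measured", "known", "first", "only" and "open" are said of these compounds alone.

Of the compounds shown here, three built on one shared core have been measured in an ADME assay on CCRF-CEM cells (Homo sapiens) for inhibition, read by cell counting; a lower number here means a stronger inhibitor, a higher number a weaker inhibitor. Compound 1 `CSc1nc(OCCCNc2ccnc3cc(Cl)ccc23)c(C#N)c(-c2ccccc2)n1` gives 3300 nM. Compound 2 `CSc1nc(NCCCCNc2ccnc3cc(Cl)ccc23)c(C#N)c(-c2cccc([N+](=O)[O-])c2)n1` gives 2100 nM, and compound 3 `COc1ccc(-c2nc(SC)nc(NCCCCNc3ccnc4cc(Cl)ccc34)c2C#N)cc1` gives 2700 nM, so compound 3 stands second highest of the three numbers, with compound 1 nearest and compound 2 furthest, both within the scatter. Going by the values given here, the only measured step that exchanges one substituted phenyl for another, a 1.3-fold higher number from compound 2 to compound 3 (0.11 log units; within the scatter), stayed within the scatter. Compound 4 `CSc1nc(NCCCCNc2ccnc3cc(Cl)ccc23)c(C#N)c(-c2ccc(C)cc2)n1` carries methyl in place of methoxy on an aromatic carbon. Among the compounds with values here, no measured step changes a group of this small size, but the single step on the phenyl ring was small, so no shift beyond the scatter is expected, and no change at the digits printed from compound 3 to compound 4 (within the scatter) is the estimated step. Compound 4 is therefore expected to give about 2700 nM, between 1200 nM and 6000 nM.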

Compound 4, half-maximal inhibitory concentration: 4900 nM
Compound 4: middle estimate off by 1.8-fold (0.26 log units), on the low side; the measured number falls inside the stated range.
By their numbers in this assay, from the lowest: compounds 2, 3, 1 and 4 (each within the scatter of the next, the first and the last beyond it).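

In this assay, 4-methoxyphenyl to 4-methylphenyl gives a 1.8-fold higher number from compound 3 to compound 4 (0.26 log units; within the scatter), so this small swap at the ring's outer end cannot be told apart from repeat scatter. Going by these compounds alone, replacing 3-nitrophenyl with 4-methylphenyl gives a 2.3-fold higher number from compound 2 to compound 4 (0.37 log units; beyond the scatter), a modest change and the first step on this ring to pass beyond the scatter. Nothing available explains this difference. Still open, from the compounds shown here alone, is how an amine or a carboxylic acid at this ring position would read in this assay, and whether a longer chain there would move the number further.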